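From propoxy to (2-fluorobenzyl)oxy: working notes

The source may hold more compounds than are shown below. What is called first, only, known or untested is meant among the compounds shown, and "the series" means these compounds.

In an ADME assay on KB cells (Homo sapiens) for cytotoxicity (on this read-out lower numbers stand for an effect already at smaller amounts and higher numbers for an effect only at larger amounts of compound), compound 1 `CCOC(=O)N1[C@@H]2C=C[C@@](OC)(C(=O)c3c2cc(OC)c(OC)c3OCc2ccc(F)cc2)N1C(=O)OCC` gives 51.8 ug/mL. Compound 2 `CCCOc1c(OC)c(OC)cc2c1C(=O)[C@]1(OC)C=C[C@H]2N(C(=O)OCC)N1C(=O)OCC` gives > 300 ug/mL, which is a limit of the assay and not a number. Its standing is thus (the limit of > 300 ug/mL in this assay, at which 1 of the 2 values shown sits).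

The next change leads to compound 3 `CCOC(=O)N1[C@@H]2C=C[C@@](OC)(C(=O)c3c2cc(OC)c(OC)c3OCc2ccccc2F)N1C(=O)OCC`: 2-fluorophenyl in place of ethyl on a saturated chain carbon bound to an oxygen on an aromatic ring. It puts 2-fluorophenyl in place of ethyl on a saturated chain carbon bound to an oxygen on an aromatic ring.

Going by the values given here, only one measured step bears on this: an at least 5.7-fold higher number from compound 1 to compound 2 (0.76 log units; beyond the scatter), with ethyl in place of 4-fluorophenyl at that same place. Since that size is only a lower bound, the true step could be larger. The new change runs the opposite way, although the group entering is 2-fluorophenyl, not 4-fluorophenyl. A move to a lower number in this assay is therefore expected, beyond the scatter. The expected step is an at least 6.0-fold lower number from compound 2 to compound 3 (0.77 log units; beyond the scatter).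

For compound 3, the estimated value is 50 ug/mL, with an expected range from 20 ug/mL to 130 ug/mL.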

Compound 3, concentration for half-maximal effect: 99.7 ug/mL
Compound 3: middle estimate off by 2.0-fold (0.30 log units), on the low side; low and high end bracket the measured number.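

In this assay, the earlier step from ethyl to a fluorophenyl group at this saturated chain carbon bound to an oxygen on an aromatic ring now has a second case with a different fluorophenyl group, giving an at least 3.0-fold lower number from compound 2 to compound 3 (0.47 log units; beyond the scatter). Exchanging 4-fluorophenyl for 2-fluorophenyl at the same place gives a 1.9-fold higher number from compound 1 to compound 3 (0.28 log units; within the scatter), so the two fluorophenyl groups cannot be told apart on this read-out, and the fluorine's place on that ring makes no difference that can be read here. The size of the ethyl to 2-fluorophenyl change remains only a lower bound because the value of compound 2 is a limit of the assay and not a number: the limit of > 300 ug/mL in this assay, at which 1 of the 3 values shown sits.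

The compounds shown leave open whether the fluorine matters at all at this place, which an unsubstituted benzyl group would address, and whether an aromatic ring is needed or a longer chain such as hexyl in place of propyl would also give a number inside the measured range. Also open, on these data alone, is how a chlorine or a methoxy group on the benzyl ring would read in this assay.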